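This account rests on a few compounds, and the source may have more. Where it says the series, first, only, none or still open, it means among the compounds named here.

Compound 1 `O=C1OCc2cc(N(Cc3ccc(C4CCCCC4)cn3)C(=O)[C@H]3CCN3S(=O)(=O)c3c(F)c(F)c(F)c(F)c3F)ccc21` and compound 2 `O=C([C@H]1CCN1S(=O)(=O)c1c(F)c(F)c(F)c(F)c1F)N(Cc1ccc(C2CCCCC2)cc1)c1ccc2c(=O)[nH]ccc2c1` are two members of one series. In a functional assay on MDA-MB-231 cells (Homo sapiens) for antiproliferative activity, with a stated time of 72 h (on this read-out higher numbers stand for an effect only at larger amounts of compound and lower numbers for an effect already at smaller amounts), compound 1 gives 900 nM, while compound 2 gives 1400 nM; these two numbers lie within the usual scatter of each other, so compound 1 stands level with compound 2 rather than apart from it. Compound 3 `O=C([C@H]1CCN1S(=O)(=O)c1c(F)c(F)c(F)c(F)c1F)N(Cc1ccc(C2CCCCC2)cn1)c1cc2[nH]ncc2cc1F` is reached from compound 1 by a single change: a group of 10 heavy atoms (7 carbon, 2 nitrogen, 1 fluorine; one five-membered aromatic ring with 2 hetero atoms, one six-membered aromatic ring of carbon only) in place of a group of 10 heavy atoms (8 carbon, 2 oxygen; one five-membered non-aromatic ring with 1 hetero atom, one six-membered aromatic ring of carbon only), on an amide-type nitrogen. Going by the values given here, no measured pair shows such a swap, so the step is expected to stay within the scatter, with the expected step of a 1.1-fold lower number from compound 1 to compound 3 (0.05 log units; within the scatter) pointing to no real shift. Compound 3 is therefore expected to give about 800 nM in this assay, within 250 nM to 2500 nM.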

Compound 3, half-maximal effective concentration: 2300 nM
Compound 3: the middle estimate sits 2.9-fold (0.46 log units) below what was measured, and the stated range covers the measured number.
By their numbers in this assay, from the lowest: compounds 1, 2 and 3 (each within the scatter of the next, the first and the last beyond it).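

Going by these compounds alone, this is the first single change at the amide-type nitrogen that can be read on its own: in this assay, 5-fluoro-1H-indazol-6-yl entering in place of the earlier group gives a 2.6-fold higher number from compound 1 to compound 3 (0.41 log units; beyond the scatter) and so a modest step beyond the scatter. The group at this place therefore affects the read-out, even though the two groups have the same heavy-atom count. No measurement shown here explains the step.

On these data alone, it remains open how much of the step belongs to the fluorine and how much to the ring system. Also open, as far as these compounds go, is how an amine or a carboxylic acid on the ring entering here would fare.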